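From Dichlorophenyl to Difluorophenyl: An Expected Read-Out

The source may report more compounds than this note shows. Statements on the series, on what has been measured and on what is new or still open speak of the compounds shown alone.

Of the compounds shown here, two have been measured so far in a functional assay on CCRF-CEM cells (Homo sapiens) for cytotoxicity, read by sulforhodamine B assay, with a stated time of 48 h, tested at 0.01 uM; a lower number here means a stronger effect, a higher number a weaker effect of the compound at the concentration tested. Compound 1, `COc1cc(-c2cc(/C=C/C(=O)c3ccc(Cl)c(Cl)c3)[nH]n2)cc(OC)c1OC`, gives 98%. Compound 2, `COc1ccc(-c2cc(/C=C/C(=O)c3ccc(N)cc3)[nH]n2)cc1OC`, gives 97%. These two numbers lie within the usual scatter of each other, so neither compound can be said to act more strongly than the other at this concentration; both readings sit close to the level that means little or no effect on the cells. Compound 1 thus stands at a reading that is, for practical purposes, the same as that of compound 2.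

Compound 3, `COc1cc(-c2cc(/C=C/C(=O)c3ccc(F)c(F)c3)[nH]n2)cc(OC)c1OC`, has not yet been measured. It differs from compound 1 in one place: 3,4-difluorophenyl in place of 3,4-dichlorophenyl on a carbonyl carbon. Both compounds keep the same core and the same carbonyl-bearing chain; only the two halogens on the ring at the carbonyl carbon change.

Since the two measured compounds already give readings within the scatter of each other, and both lie near the level of no effect, no step beyond the scatter is expected in this assay. The step from compound 1 to compound 3 is estimated as a number 1 percentage points lower from compound 1 to compound 3 (within the scatter). For compound 3, the expected reading in this assay is 97%, with a likely range from 88% to 105%.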

Compound 3, a percentage reported as activity, at one concentration (the size of the read-out at that concentration, not a potency): 99%
Compound 3: middle estimate off by 2 percentage points, on the low side, and the stated range covers the measured number.
By their numbers in this assay, from the lowest: compounds 2, 1 and 3 (each within the scatter of the next).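

In this assay, 3,4-difluorophenyl in place of 3,4-dichlorophenyl on a carbonyl carbon gives a number 1 percentage points higher from compound 1 to compound 3 (within the scatter) and this is the first comparison shown in which only one place in the structure differs. At the tested concentration, the two chlorine atoms and the two fluorine atoms on this ring cannot be told apart, but this is a weak finding: compound 3 at 99% sits near the level that means little or no effect on the cells, as does compound 1, so there is little effect for the change to alter. Nothing available explains this result or links it to any property of the two groups.

The compounds shown leave open whether a different group on this ring, such as a carboxylic acid or a nitrile in place of the two halogens, would shift the reading beyond the usual scatter. They also leave open whether compound 1 and compound 3 would separate at a higher concentration, where the cells might respond more clearly.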